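The source may report more compounds than this note shows. Statements on the series, on what has been measured and on what is new or still open speak of the compounds shown alone.

Of the compounds shown here, three built on a shared core have been measured in a physicochemical assay for lipophilicity, read by HPLC, at pH 7.5; a higher number here means a more lipophilic compound, a lower number a more polar compound. Compound 1 `N#Cc1c(-c2ccc(Br)cc2)nc2cnccc2c1NCC(N)=O` gives 1.9. Compound 3 `CC[C@@H](Nc1c(C#N)c(-c2ccc(-c3ccccc3NC)cc2)nc2cnccc12)C(N)=O` gives 2.5. Compound 2 `CCCCC(Nc1c(C#N)c(-c2ccc(-c3ccccc3OCC)cc2)nc2cnccc12)C(N)=O` gives 3.6, the highest of the three numbers; its gap to compound 3 lies beyond the usual scatter of this assay, and its gap to compound 1 is wider still.

Compound 4 `CCOc1ccccc1-c1ccc(-c2nc3cnccc3c(N[C@H](CC(C)C)C(N)=O)c2C#N)cc1` has not yet been measured in this assay. It is made of the same atoms as compound 2, joined differently: 1-carbamoyl-3-methylbutyl in place of 1-carbamoylpentyl on a nitrogen on an aromatic ring The chain keeps its count of heavy atoms, its single hydrogen-bond donor and its single hydrogen-bond acceptor; what changes is only how the carbons are arranged. No measured pair among these three compounds differs in this way alone, so there is no step of that kind to read off directly. With no atoms added or removed, the expectation is that the step from compound 2 to compound 4 will be a number 0.10 log units lower from compound 2 to compound 4 (within the scatter), which falls within the scatter of this assay, if anything leaning slightly downward. On that basis compound 4 is estimated to give 3.5 in this assay, with a range from 3.1 to 3.9.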

Compound 4, distribution coefficient: 3.4
The estimate for compound 4 lay 0.10 log units above the measured number; the measured number falls inside the stated range.
By their numbers in this assay, from the lowest: compound 1; then compound 3; then compounds 4 and 2 (each within the scatter of the next).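

Among the compounds shown here, the chain on the nitrogen on an aromatic ring can be read on its own for the first time, since compounds 1, 2 and 3 differ from one another in more than one place. In this assay, putting 1-carbamoyl-3-methylbutyl in place of 1-carbamoylpentyl gives a number 0.20 log units lower from compound 2 to compound 4 (within the scatter) and so leaves compound 2 and compound 4 indistinguishable: at this position, rearranging the carbons of a chain with the same atoms, from a straight to a branched form, does not separate the two compounds beyond the scatter. Nothing measured here offers an explanation for this result.

This single pair speaks only to one rearrangement of these atoms, and compound 4 carries a defined stereocentre that compound 2 does not, so the opposite arrangement at that centre remains an open question. From the compounds shown here alone, it also remains open how far the reading would move with a change in the atoms themselves, such as a carboxylic acid in place of the carboxamide, an amine on the chain, or a longer chain.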